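Acetylation of the Aminopyridine in a Trifluoromethylphenyl Amide Series

The source may report more compounds than this note shows. Statements on the series, on what has been measured and on what is new or still open speak of the compounds shown alone.

Compound 1 `C[C@H](NC(=O)c1ccc(-c2ccc(N)nc2)cc1)C(=O)Nc1ccc(Cl)c(C(F)(F)F)c1`: 5950 nM
Compound 2 `O=C(NC1CC1)c1cncc(-c2ccc(C(=O)N[C@H]3CN[C@@H](C(=O)Nc4ccc(Cl)c(C(F)(F)F)c4)C3)cc2)c1`: 65300 nM
Compound 3 `CS(=O)(=O)Nc1ccc(-c2ccc(C(=O)N[C@H]3CN[C@@H](C(=O)Nc4ccc(Cl)c(C(F)(F)F)c4)C3)cc2)cn1`: 45000 nM

Of the compounds shown here, three have been measured in a functional assay on K562 cells (Homo sapiens) for inhibition, read by MTT assay, with a stated time of 48 h; on this read-out higher numbers stand for weaker inhibition and lower numbers for stronger inhibition. Compound 1 gives the lowest number of the three; compound 3 lies higher and compound 2 higher still, both gaps beyond the usual scatter. Within the data shown here, compound 2 and compound 3 share a different core from compound 1, and the single step between them, a 1.5-fold lower number from compound 2 to compound 3 (0.16 log units; within the scatter), replaces one pyridyl substituent by another and stays within the scatter.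

Compound 4 `CC(=O)Nc1ccc(-c2ccc(C(=O)N[C@@H](C)C(=O)Nc3ccc(Cl)c(C(F)(F)F)c3)cc2)cn1` is the next compound. It differs from compound 1 by acetyl in place of hydrogen on a nitrogen on an aromatic ring, so that the amino group becomes acetamido and the 6-aminopyridin-3-yl becomes 6-acetamidopyridin-3-yl. Among the measured compounds shown here, no measured step tests this change on the core of compound 1; the only step available, from compound 2 to compound 3, concerns a different pyridyl substituent and is small. The expectation is therefore a step of about a 1.3-fold higher number from compound 1 to compound 4 (0.13 log units; within the scatter), that is, little movement beyond the scatter. Compound 4 is thus estimated at 8000 nM, within 2500 nM to 25000 nM.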

Compound 4, half-maximal inhibitory concentration: 107000 nM
Beside the measured number, compound 4's estimate is 13-fold (1.13 log units) below it, outside the stated range (above it).
By their numbers in this assay, from the lowest: compound 1; then compounds 3, 2 and 4 (each within the scatter of the next, the first and the last beyond it).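

In this assay, acetyl in place of hydrogen on the nitrogen of the 6-aminopyridin-3-yl gives an 18-fold higher number from compound 1 to compound 4 (1.25 log units; beyond the scatter), so on the core of compound 1 this single change, amino to acetamido, is a large one. Among these compounds, the only earlier step, a 1.5-fold lower number from compound 2 to compound 3 (0.16 log units; within the scatter), exchanged one pyridyl substituent for another on a different core and stayed within the scatter, so it gave no sign that a change on this pyridyl could move the number so far. Nothing available here accounts for the size of the new step.

The compounds shown leave open whether the free amino group itself matters or acetyl in particular is the problem, as a methyl group or a propanoyl group on that nitrogen would tell. They also leave open how the same acetyl change would read on the core shared by compound 2 and compound 3.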